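Moving the bromine on a pyrazine-free reading

The compounds below may be only part of what the source reports. "The series", "measured", "known", "first", "only" and "open" are said of these compounds alone.

Moving the Bromine in Compound 3

Measured in a functional assay on HeLa cells (Homo sapiens) for antiproliferative activity, read by MTT assay, with a stated time of 48 h; a higher number here means a weaker inhibitor, a lower number a stronger inhibitor:

Compound 1 `Clc1ccc(CSc2nnc(-c3cnccn3)o2)cc1` - 24600 nM
Compound 2 `Clc1ccc(CSc2nnc(-c3cnccn3)s2)cc1` - 18900 nM
Compound 3 `Brc1ccccc1CSc1nnc(-c2cnccn2)n1-c1ccccc1` - > 50000 nM

Compound 3 stands at the limit of > 50000 nM in this assay, at which 1 of the 3 values shown sits, so its entry is a limit and not a number. Compound 4 `Brc1cccc(CSc2nnc(-c3cnccn3)n2-c2ccccc2)c1` carries 3-bromophenyl in place of 2-bromophenyl on a saturated chain carbon bound to a sulfur. Within the data shown here, no measured pair shows a change of this kind, so only a modest step towards stronger inhibition is expected in this assay, and possibly none beyond the scatter. Compound 4 is estimated at about 35000 nM. Its expected range runs from 15000 nM to 50000 nM. The estimate means an expected at least 1.4-fold lower number from compound 3 to compound 4 (0.15 log units; that floor lies within the scatter).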

Compound 4, half-maximal inhibitory concentration: 9580 nM
Compound 4: middle estimate off by 3.7-fold (0.56 log units), on the high side; the measured number lies below the stated range.
By their numbers in this assay, from the lowest: compounds 4, 2 and 1 (each within the scatter of the next, the first and the last beyond it). At a limit, above all of these: compound 3.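

In this assay, moving the bromine gives an at least 5.2-fold lower number from compound 3 to compound 4 (0.71 log units; beyond the scatter). Among these compounds, this is the first sign that the position of the bromine on this ring matters at the place on a saturated chain carbon bound to a sulfur, which the earlier compounds could not show. The entry for compound 3 is a limit and not a number, so the step has only a floor: the limit of > 50000 nM in this assay, at which 1 of the 4 values shown sits.

From the compounds shown here alone, it remains open how an amine or a carboxylic acid in place of the bromine would read in this assay. Going by these compounds, a longer chain in place of the saturated chain carbon also remains open.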